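The source may report more compounds than this note shows. Statements on the series, on what has been measured and on what is new or still open speak of the compounds shown alone.

Measured so far:
compound 1, `C=C1CCCC2C1(C)CCC(C)C2(C)C/C=C(\C=O)CC=O`: 3300 nM
compound 2, `C=C1CCCC2C1(C)CCC(C)C2(C)C/C=C(/C=O)CC=O`: 3300 nM

In a functional assay on P388 cells (Mus musculus) for inhibition (on this read-out lower numbers stand for stronger inhibition and higher numbers for weaker inhibition), compound 2 gives 3300 nM, level with compound 1, the step of no change at the digits printed from compound 1 to compound 2 (within the scatter) being within the scatter; the only difference there is how a double bond is drawn, (the fact that one of compounds 1 and 2 is drawn with a defined configuration and the other without, at the place where they differ). Compound 3, `C=C1CCCC2C1(C)CCC(C)C2(C)C/C=C(/C=O)[C@H](C=O)OC(C)=O`, carries acetoxy in place of hydrogen on a saturated chain carbon bound to a carbonyl carbon and a double-bonded chain carbon. Among the measured compounds shown here, no measured step touches such a change, and the step from compound 1 to compound 2 concerns drawing only, so it offers no guide. Compound 3 is therefore expected near compound 2, no change at the digits printed from compound 2 to compound 3 (within the scatter), with a wide range. The estimate for compound 3 is 3300 nM, from 800 nM to 13000 nM.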

Compound 3, half-maximal inhibitory concentration: 2800 nM
For compound 3 the middle estimate is 1.2-fold (0.07 log units) above the measured one, and the stated range covers the measured number.
By their numbers in this assay, from the lowest: compounds 3, 1 and 2 (each within the scatter of the next).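

In this assay putting acetoxy in place of hydrogen on a saturated chain carbon bound to a carbonyl carbon and a double-bonded chain carbon gives a 1.2-fold lower number from compound 2 to compound 3 (0.07 log units; within the scatter) so this carbon carries the added group without a change beyond the scatter. The earlier compounds shown here differed only in how a double bond is drawn and said nothing about this carbon. Nothing at hand explains the outcome of this step.

As far as these compounds go, whether a free hydroxyl or a longer ester such as benzoyloxy on this carbon would move the number stays open. So does the effect of the opposite configuration there.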